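Chlorine pattern on the benzyl ring: working notes, compound 4

This account rests on a few compounds, and the source may have more. Where it says the series, first, only, none or still open, it means among the compounds named here.

The three measured compounds share one core and differ only in where chlorine sits on the phenyl ring of the benzyl group. Compound 1 `O=C(O)Cn1c(SCc2ccc(Cl)cc2)nc2ccccc21` carries a 4-chlorophenyl group, and in an assay on HEK293 cells for displacement of a labelled ligand from prostaglandin D2 receptor 2 (Homo sapiens) (on this read-out higher numbers stand for weaker inhibition and lower numbers for stronger inhibition), compound 1 gives 160 nM. Compound 2 `O=C(O)Cn1c(SCc2ccccc2Cl)nc2ccccc21` differs from compound 1 by 2-chlorophenyl in place of 4-chlorophenyl on a saturated chain carbon bound to a sulfur; in this assay compound 2 gives 370 nM, and the step is a 2.3-fold higher number from compound 1 to compound 2 (0.36 log units; beyond the scatter). Compound 3 `O=C(O)Cn1c(SCc2ccc(Cl)c(Cl)c2)nc2ccccc21` arises from compound 1 by chloro in place of hydrogen on an aromatic carbon; in this assay compound 3 gives 380 nM, and the step is a 2.4-fold higher number from compound 1 to compound 3 (0.38 log units; beyond the scatter). The values of compound 2 and compound 3 lie within the scatter of each other.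

Compound 4 `O=C(O)Cn1c(SCc2cc(Cl)ccc2Cl)nc2ccccc21` is not yet measured. It arises from compound 2 by chloro in place of hydrogen on an aromatic carbon. Within the data shown here, this is the same kind of change as the one from compound 1 to compound 3, but not the same: in compound 3 the entering chloro sits ortho to a chloro group and meta to a large group, whereas in compound 4 it sits meta to a large group and para to a chloro group. The change occurs twice among the compounds shown, with one measured instance, a 2.4-fold higher number from compound 1 to compound 3 (0.38 log units; beyond the scatter).

The step from compound 2 to compound 4 in this assay is expected to be a 2.2-fold higher number from compound 2 to compound 4 (0.33 log units; beyond the scatter), resting on that single measured instance, a 2.4-fold higher number from compound 1 to compound 3 (0.38 log units; beyond the scatter), with a wider allowance since the surroundings of the place differ. Compound 4 is expected to give about 800 nM in this assay, between 320 nM and 2000 nM.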

Compound 4, half-maximal inhibitory concentration: 470 nM
Compound 4: middle estimate off by 1.7-fold (0.23 log units), on the high side; low and high end bracket the measured number.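

In this assay, the chloro entering para to a chloro group gives a 1.3-fold higher number from compound 2 to compound 4 (0.10 log units; within the scatter), so on this core the added chloro produces no shift that can be told from the usual scatter of repeated measurements. Set beside the earlier instance, the step does not differ beyond what two such steps would be expected to scatter, so the result is compatible with the change carrying from one core to the other, although the earlier step lies beyond the scatter and this one within it: the same change on two cores in this assay, a 2.4-fold higher number (0.38 log units; beyond the scatter) from compound 1 to compound 3 and a 1.3-fold higher number (0.10 log units; within the scatter) from compound 2 to compound 4, 1.9-fold (0.27 log units) apart, within the scatter of two such steps. This does not show that the step has a fixed size, or that its size is independent of the surroundings, as there are only two instances and they differ both in the chlorine already present on the ring and in where the entering chloro sits, so these two influences cannot be separated.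

The compounds shown leave open whether a step of this kind would hold if fluoro, methyl or methoxy entered on the same aromatic carbon in place of chloro. Also open, as far as these compounds go, is how the read-out would respond if an amide replaced the carboxylic acid, or if a longer chain carried that acid, as all four compounds share that part unchanged.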